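A few compounds are considered here, and "the series" means these few. Any claim that something is new, unique, unknown or untested is made for them only; others in the source may bear on it.

In a functional assay on ileum (Cavia porcellus) for antagonist activity (on this read-out higher numbers stand for weaker inhibition and lower numbers for stronger inhibition), compound 3 (`N#Cc1ccc(OCCCOc2ccc3c(O)c([N+](=O)[O-])c(=O)oc3c2)cc1`) gives > 10000 nM, which is a limit and not a number. Compound 2 (`CCc1cc2c(O)c([N+](=O)[O-])c(=O)oc2cc1OCCCOc1ccccc1`) gives > 10000 nM, also a limit. Compound 3 therefore sits at the limit of > 10000 nM in this assay, at which 2 of the 3 values shown sit.

Compound 4 (`Cc1ccc(OCCCOc2ccc3c(O)c([N+](=O)[O-])c(=O)oc3c2)cc1`) has methyl in place of cyano on an aromatic carbon.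

Among the measured compounds shown here, the one measured step is an at least 4.0-fold higher number from compound 1 to compound 3 (0.60 log units; beyond the scatter). For the measured compounds named here, it swaps 4-methylbenzyl for 4-cyanophenoxy, so it bears on this change only indirectly, and no measured step isolates the cyano group. Compound 1 (`Cc1ccc(CCCCOc2ccc3c(O)c([N+](=O)[O-])c(=O)oc3c2)cc1`), which carries a methyl, gives 2500 nM, so a modest shift towards stronger inhibition is expected. It remains possible that compound 4 also reaches a limit. The expected step is an at least 1.6-fold lower number from compound 3 to compound 4 (0.22 log units; that floor lies within the scatter). For compound 4 the estimate is 6000 nM, with an expected range of 2000 nM to 15000 nM.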

Compound 4, half-maximal inhibitory concentration: 4500 nM
Compound 4: middle estimate off by 1.3-fold (0.12 log units), on the high side, within the range that was stated.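

In this assay, among the compounds shown here, methyl in place of cyano gives an at least 2.2-fold lower number from compound 3 to compound 4 (0.34 log units; beyond the scatter), the first measured step that isolates the group at this place, para to a large group. The other new step, 4-methylphenoxy in place of 4-methylbenzyl, is a 1.8-fold higher number from compound 1 to compound 4 (0.26 log units; within the scatter), so compounds 1 and 4 cannot be told apart here. Together these steps tie the earlier loss in compound 3 to the cyano group rather than to the exchange of 4-methylbenzyl for a phenoxy group.

As far as these compounds go, whether a chlorine, a methoxy group or an amine at this place would give a lower number than methyl stays open. So does the effect of a longer chain on the 4-methylphenoxy compound.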